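The source may report more compounds than this note shows. Statements on the series, on what has been measured and on what is new or still open speak of the compounds shown alone.

Compound 1 `ClCc1ccc(Cn2cnc3c(Cl)ncnc32)cc1` and compound 2 `ClCc1cccc(Cn2cnc3c(Cl)nc(Cl)nc32)c1` were both tested in a functional assay on SNB-19 cells (Homo sapiens) for cytotoxicity, read by sulforhodamine B assay, with a stated time of 48 h; a lower number here means that less compound is tolerated, a higher number that more compound is tolerated. In this assay compound 1 gives 89100 nM, while compound 2 gives 8920 nM. Among the compounds with values here, compound 2 thus stands at the lowest of the two numbers measured so far, with compound 1 as its only neighbour at a higher number, a gap that lies beyond the usual scatter of repeated measurements. The next compound, compound 3 `Nc1nc(Cl)c2ncn(Cc3cccc(CCl)c3)c2n1`, has not yet been measured in this assay. It differs from compound 2 in one place: amino in place of chloro on an aromatic carbon. The change sits on an aromatic carbon of the shared core, between two ring nitrogen atoms. Within the data shown here, no measured pair tells how such a swap plays out here, so the expectation rests only on this one change. The step from compound 2 to compound 3 is estimated at a 2.2-fold higher number from compound 2 to compound 3 (0.35 log units; beyond the scatter), toward a higher number. Compound 3 is therefore expected to give about 20000 nM, within a range from 5000 nM to 80000 nM.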

Compound 3, concentration lethal to 50% of the cells: 46800 nM
The estimate for compound 3 lay 2.3-fold (0.37 log units) below the measured number, and the stated range covers the measured number.
By their numbers in this assay, from the lowest: compound 2; then compounds 3 and 1 (each within the scatter of the next).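

In this assay, within the data shown here, the swap of chloro for amino on this aromatic carbon, between two ring nitrogen atoms, gives a 5.2-fold higher number from compound 2 to compound 3 (0.72 log units; beyond the scatter) as the first single-change reading at this position. The step is modest but lies beyond the scatter, so what sits on this carbon of the shared core does change how much compound the cells tolerate. Nothing available explains the shift, so it stands as an observation without a known cause.

One swap cannot show whether the change comes from losing the chloro group or from gaining the amino group, and a hydrogen, a methoxy group or a methylamino group on this carbon would help to separate the two. Also open, from the compounds shown here alone, is whether the same swap would give a similar step on a core without the remaining chloro group, which sits meta to this position.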